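Methyl to methoxy on the pendant aryl of compound 1

The source may hold more compounds than are shown below. What is called first, only, known or untested is meant among the compounds shown, and "the series" means these compounds.

Within the data shown here, compound 1 `COc1ncc(-c2ccc3c(c2)N(c2ccc(C)cc2)C(=O)CO3)cc1NS(=O)(=O)c1ccc(F)cc1` is the only member of this set with a measured number: in a functional assay on A549 cells (Homo sapiens) for antiproliferative activity, read by MTT assay, with a stated time of 72 h (on this read-out lower numbers stand for stronger inhibition and higher numbers for weaker inhibition), compound 1 gives 5870 nM. Compound 2 `O=C1COc2ccc(-c3cccc(NS(=O)(=O)c4ccc(F)cc4)c3)cc2N1C1CC1` reaches only a limit of the assay in this assay, > 40000 nM. Compound 3 `COc1ccc(N2C(=O)COc3ccc(-c4cnc5ccccc5c4)cc32)cc1` likewise reaches only a limit, > 40000 nM. Among the measured compounds shown here, two of three results thus sit at the limit of > 40000 nM in this assay, at which 2 of the 3 values shown sit, so compound 1 stands alone as the single quantified point and there is no measured pair differing in one place from which a step could be read.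

Compound 4 `COc1ccc(N2C(=O)COc3ccc(-c4cnc(OC)c(NS(=O)(=O)c5ccc(F)cc5)c4)cc32)cc1` is not yet measured. It differs from compound 1 by methoxy in place of methyl on an aromatic carbon; the same difference, read one bond further out, is 4-methylphenyl to 4-methoxyphenyl. For the measured compounds named here, with no measured step of this kind available, no change beyond the usual scatter is expected from compound 1 to compound 4, and the step is estimated as a 1.1-fold lower number from compound 1 to compound 4 (0.03 log units; within the scatter). Compound 4 is expected to give about 5500 nM in this assay, within 2500 nM to 13000 nM.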

Compound 4, half-maximal inhibitory concentration: 1350 nM
For compound 4 the middle estimate is 4.1-fold (0.61 log units) above the measured one, outside the stated range (below it).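

In this assay, this place on the aromatic ring, para to a large group, proves responsive: methoxy in place of methyl gives a 4.3-fold lower number from compound 1 to compound 4 (0.64 log units; beyond the scatter). Among these compounds, this is the first measured step, and it shows that a single added oxygen at this place can move the number beyond the scatter, though only modestly and only in this one pair. Nothing among the measurements shown bears on why the number moves.

Open, going by these compounds, is how an ethoxy group, a dimethylamino group or a chlorine atom at the same place would compare with methoxy. Also open, on these data alone, is whether the step keeps its size when other parts of the core of compound 4 change, as the reading rests on one pair.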